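The source may report more compounds than this note shows. Statements on the series, on what has been measured and on what is new or still open speak of the compounds shown alone.

Four compounds share one core. Compound 1 `O=C(Nc1ccc(Cl)cc1Cl)c1ccc(S(=O)(=O)Nc2ccccc2)cc1` was tested in a functional assay on HEK293 cells for agonist activity at probable G-protein coupled receptor 27 (Homo sapiens), read by a luciferase reporter and beta-arrestin recruitment, with a stated time of 10 min (a higher number here means that more compound is needed for the effect, a lower number that less compound is needed), and gave only a limit, > 100000 nM, with no number behind it (the limit of > 100000 nM in this assay, at which 1 of the 3 values shown sits). Compound 2 `CN(c1ccccc1)S(=O)(=O)c1ccc(NC(=O)c2ccc(Cl)cc2Cl)cc1` gives 2570 nM in this assay, the lower of the two numbers shown, while compound 3 `O=C(Nc1ccc(S(=O)(=O)Nc2ccccc2)cc1)c1ccc(I)cc1F` gives 5130 nM, a reading that lies within the scatter of compound 2. Compound 4 `O=C(Nc1ccc(S(=O)(=O)Nc2ncccn2)cc1)c1ccc(Cl)cc1Cl` has not yet been measured. It differs from compound 2 at one place: (pyrimidin-2-yl)amino in place of methyl(phenyl)amino on a sulfonyl sulfur. Among the measured compounds shown here, no step between measured compounds is known, so the direction of this change rests on little. Compound 4 is expected to give about 5000 nM in this assay, somewhere between 1000 nM and 40000 nM. The expected step of a 1.9-fold higher number from compound 2 to compound 4 (0.29 log units; within the scatter) is modest, toward more compound being needed, and may not exceed the scatter.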

Compound 4, half-maximal effective concentration: > 100000 nM
Compound 4: only a limit was reported; the forecaster's own chance of this, stated with the estimate: 25%; at least 20-fold (1.30 log units) between middle value and limit.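

In this assay, among the compounds shown here, the place on the sulfonyl sulfur turns out to be sensitive: (pyrimidin-2-yl)amino in place of methyl(phenyl)amino gives an at least 38-fold higher number from compound 2 to compound 4 (1.59 log units; beyond the scatter), the first readable step here and one beyond the scatter. Compound 4 gives > 100000 nM, which is a limit and not a number. Such limits now recur in this small set: the limit of > 100000 nM in this assay, at which 2 of the 4 values shown sit.

From the compounds shown here alone, the ring and the methyl on the nitrogen change together in this one step, so which of them carries it stays open. Going by these compounds, how a methyl(pyrimidin-2-yl)amino group would read on the same core remains unknown.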